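Quinone series: amino acid substituent in place of methoxy

The source may hold more compounds than are shown below. What is called first, only, known or untested is meant among the compounds shown, and "the series" means these compounds.

Measured so far:
compound 1 `C=C1[C@H](C)CCC[C@]1(C)CC/C(C)=C/CC1=C(O)C(=O)C=C(N[C@@H](C(=O)O)[C@H](C)O)C1=O` — 4.6 ug/mL
compound 2 `COC1=CC(=O)C(O)=C(C/C=C(\C)CC[C@@]2(C)CCC=C(C)[C@H]2C)C1=O` — 2 ug/mL
compound 3 `CC1=CCC[C@H]2[C@](C)(CC3=C(O)C(=O)C=C(N[C@@H](CO)C(=O)O)C3=O)[C@@H](C)CC[C@]12C` — 3.8 ug/mL

All three numbers come from an ADME assay on L1210 cells (Mus musculus) for cytotoxicity, with a stated time of 48 h; on this read-out lower numbers stand for stronger inhibition and higher numbers for weaker inhibition. Compound 2 gives the lowest number of the three; its gap to compound 3 is within the scatter, its gap to compound 1 lies just beyond it. Compound 1 and compound 3, the two that carry an amino acid substituent on the core, both give higher numbers than compound 2, while compound 2 is the only one with methoxy at that position.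

The step to compound 4 `CC1=CCC[C@](C)(CC/C(C)=C/CC2=C(O)C(=O)C=C(N[C@H](C(=O)O)[C@H](C)O)C2=O)[C@@H]1C` changes compound 2 in one place: (1-carboxy-2-hydroxypropyl)amino in place of methoxy on a double-bonded ring carbon. Apart from this, compound 4 keeps a terpene portion close to that of compound 2, so compounds 1 and 3 are the nearest guides for what the entering group does.

Going by the values given here, no measured pair shows this change in isolation. Given compound 1 at 4.6 ug/mL and compound 3 at 3.8 ug/mL, the expectation is a modest shift toward weaker inhibition in this assay, at or just beyond the scatter. The estimated step of a 2.0-fold higher number from compound 2 to compound 4 (0.30 log units; within the scatter) is small. Compound 4 is expected to give 4 ug/mL, in a range from 1.5 ug/mL to 10 ug/mL.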

Compound 4, half-maximal inhibitory concentration: > 10 ug/mL
Compound 4: only a limit was reported; the forecaster's own chance of this, stated with the estimate: 5%; middle value at least 2.5-fold (0.39 log units) away from the limit.
By their numbers in this assay, from the lowest: compounds 2, 3 and 1 (each within the scatter of the next, the first and the last beyond it). At a limit, above all of these: compound 4.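

In this assay compound 4 gives only a limit, > 10 ug/mL, so what follows is a bound on the change and not a measure of it. Placing (1-carboxy-2-hydroxypropyl)amino in place of methoxy on a double-bonded ring carbon gives an at least 5.0-fold higher number from compound 2 to compound 4 (0.69 log units; beyond the scatter), the first single-place change that can be read at this position. The earlier compounds shown here could not show this, as no two of them differed in one place only; this step shows that the number in this read-out does respond to the group at this ring carbon, and that methoxy and this amino acid substituent are not interchangeable there.

The compounds shown leave open which part of the entering group carries the step: the amino link, the carboxylic acid or the side-chain hydroxy. As far as these compounds go, a plain alkylamine or the methyl ester of the carboxylic acid on the same ring carbon would separate these parts, and the full size of the step remains unknown while compound 4 stands at a limit.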